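Removing the hydroxyacetyl cap from the pyrrolidine ring

The source may hold more compounds than are shown below. What is called first, only, known or untested is meant among the compounds shown, and "the series" means these compounds.

Compound 2 `CN1CCN(c2ccc(Nc3ncc4nc(Nc5ccc(F)cc5)n([C@H]5CCN(C(=O)CO)C5)c4n3)cc2)CC1` gives 380 nM in a functional assay on HCC827 cells (Homo sapiens) for antiproliferative activity, read by MTT assay, with a stated time of 72 h (on this read-out lower numbers stand for stronger inhibition and higher numbers for weaker inhibition), and has the higher number of the two measured compounds; compound 1 `CN1CCN(c2ccc(Nc3ncc4nc(Nc5ccc(F)cc5)n([C@@H]5CCN(C(=O)OC(C)(C)C)C5)c4n3)cc2)CC1` gives 27 nM. Compound 3 `CN1CCN(c2ccc(Nc3ncc4nc(Nc5ccc(F)cc5)n([C@@H]5CCNC5)c4n3)cc2)CC1` carries pyrrolidin-3-yl in place of 1-((hydroxymethyl)carbonyl)pyrrolidin-3-yl on an aromatic nitrogen. Among the compounds with values here, the only measured step at that position, a 14-fold higher number from compound 1 to compound 2 (1.15 log units; beyond the scatter), shows that changing the group on this ring nitrogen shifts the number strongly, though in no direction that can be carried over to a change that simply removes the group. For compound 3 a modest improvement is expected, a 2.5-fold lower number from compound 2 to compound 3 (0.40 log units; beyond the scatter), with wide uncertainty. The estimated value for compound 3 is 150 nM, within 30 nM to 800 nM.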

Compound 3, half-maximal inhibitory concentration: 300 nM
Beside the measured number, compound 3's estimate is 2.0-fold (0.30 log units) below it; measured number inside the range.
By their numbers in this assay, from the lowest: compound 1; then compounds 3 and 2 (each within the scatter of the next).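

In this assay, replacing the hydroxyacetyl cap with the bare pyrrolidin-3-yl gives a 1.3-fold lower number from compound 2 to compound 3 (0.10 log units; within the scatter) and so leaves the number within the scatter: these two groups cannot be told apart here. Removing the tert-butoxycarbonyl group instead gives an 11-fold higher number from compound 1 to compound 3 (1.05 log units; beyond the scatter) and confirms that, among these three compounds, only the tert-butoxycarbonyl compound stands apart. Nothing measured here accounts for this gap. Still open, on these data alone, is whether another carbamate, such as a benzyl carbamate, or a simple methyl or acetyl group on this ring nitrogen would bring the number close to that of compound 1.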